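Swapping a sulfonamide for a pyridylmethyl amine

The compounds below may be only part of what the source reports. "The series", "measured", "known", "first", "only" and "open" are said of these compounds alone.

Of the compounds shown here, two have been measured in an assay on isolated protein for inhibition of microsomal triglyceride transfer protein large subunit (Homo sapiens); on this read-out lower numbers stand for stronger inhibition and higher numbers for weaker inhibition. Compound 1 `O=C(Nc1ccc2c(c1)CC(NS(=O)(=O)c1ccccc1)C2)c1ccccc1-c1ccccc1` gives 710 nM, and compound 2 `Cc1cccc(C(=O)Nc2ccc3c(c2)C[C@H](NS(C)(=O)=O)C3)c1-c1ccc(C(F)(F)F)cc1` gives 34 nM. Of these two numbers, compound 2 has the lower one; compound 1 sits far above it, beyond the usual scatter of such measurements, so compound 2 is the stronger inhibitor of this pair. Compound 3 `Cc1cccc(C(=O)Nc2ccc3c(c2)C[C@H](NCc2ccccn2)C3)c1-c1ccc(C(F)(F)F)cc1` has not yet been measured. It shares the rest of its structure with compound 2 and differs in one place, on an amine nitrogen whose other neighbour is a saturated ring carbon: (pyridin-2-yl)methyl in place of methylsulfonyl on an amine nitrogen. Within the data shown here, no measured pair shows this particular change, so its effect can only be estimated. Compared with compound 2, compound 3 is expected to be somewhat weaker, with an estimated value of 150 nM, lying between 25 nM and 900 nM. The estimated step, a 4.4-fold higher number from compound 2 to compound 3 (0.64 log units; beyond the scatter), is expected to run towards weaker inhibition, although a result within the scatter cannot be excluded.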

Compound 3, half-maximal inhibitory concentration: 410 nM
For compound 3 the middle estimate is 2.7-fold (0.44 log units) below the measured one; the range from low to high includes it.
By their numbers in this assay, from the lowest: compound 2; then compounds 3 and 1 (each within the scatter of the next).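

In this assay, putting (pyridin-2-yl)methyl in place of methylsulfonyl on an amine nitrogen whose other neighbour is a saturated ring carbon gives a 12-fold higher number from compound 2 to compound 3 (1.08 log units; beyond the scatter), a large loss of inhibition. With the rest of the structure shared, this single step shows that the group on this nitrogen strongly affects the read-out, which the first two compounds could not show because they differ in more than one place. Nothing measured here explains the loss.

This change removes the methylsulfonyl group and brings in the pyridine ring at once, so the compounds shown cannot separate the two effects. Benzyl, which has a ring without the ring nitrogen, or acetyl on the same nitrogen would help to tell them apart.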